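A few compounds are considered here, and "the series" means these few. Any claim that something is new, unique, unknown or untested is made for them only; others in the source may bear on it.

The measured compounds are two. Compound 1 `O=C(Nc1ccc(-c2cnc3cc(C4=CCN(C5COC5)CC4)ccn23)cc1)c1ccc([N+](=O)[O-])o1` gives 1100 nM in a functional assay on MGC-803 cells (Homo sapiens) for antiproliferative activity, read by CCK-8 assay, with a stated time of 72 h; a lower number here means a stronger inhibitor, a higher number a weaker inhibitor. Compound 2 `O=C(Nc1ccc(-c2cnc3cc(Br)ccn23)cc1)c1ccc([N+](=O)[O-])o1` gives 750 nM in this assay.

Going by the values given here, compound 2 therefore stands beside compound 1 as one of just two numbers in this assay, and the single measured step, a 1.5-fold lower number from compound 1 to compound 2 (0.17 log units; within the scatter), shows that the two compounds cannot be told apart within the usual scatter. The next compound, compound 3 `O=C(Nc1ccc(-c2cnc3cc(Cl)ccn23)cc1)c1ccc([N+](=O)[O-])o1`, differs from compound 2 in one place: chloro in place of bromo on an aromatic carbon.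

Among the compounds with values here, only one measured step exists, and it does not concern this exchange: it swaps bromo for a larger group containing two rings, and even that larger change moved the number only within the scatter. Within the data shown here, no measured pair in this set separates bromo from chloro, so nothing in the data argues for a shift in either direction. The expectation for compound 3 in this assay is consequently a step of about a 1.1-fold higher number from compound 2 to compound 3 (0.03 log units; within the scatter), that is, no change beyond the scatter. Compound 3 is estimated at 800 nM, with a range from 400 nM to 1600 nM.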

Compound 3, half-maximal inhibitory concentration: 4620 nM
Beside the measured number, compound 3's estimate is 5.8-fold (0.76 log units) below it, outside the stated range (above it).
By their numbers in this assay, from the lowest: compounds 2 and 1 (each within the scatter of the next); then compound 3.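

In this assay, the step of a 6.2-fold higher number from compound 2 to compound 3 (0.79 log units; beyond the scatter) shows that this position, on an aromatic carbon opposite the ring nitrogen, does respond to its substituent, and that exchanging bromo for chloro, one atom for one atom, is enough to move the number beyond the scatter. The earlier comparison had made the position look tolerant, but the step of a 4.2-fold higher number from compound 1 to compound 3 (0.62 log units; beyond the scatter) now separates chloro from the larger group with its two non-aromatic rings as well, so chloro stands apart from both other substituents, while bromo and that larger group remain within the scatter of each other. Nothing available here accounts for the gap between bromo and chloro.

The compounds shown leave open whether this sensitivity is particular to these two halogens or extends to iodo, fluoro or plain hydrogen at the same place. They also leave open how a small amine, a methoxy group or a nitrile would fall relative to bromo and chloro on the otherwise unchanged core.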